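A pyridyl triazole on a cytotoxicity scaffold

The source may hold more compounds than are shown below. What is called first, only, known or untested is meant among the compounds shown, and "the series" means these compounds.

Compound 1 `C=C1C[C@]23C[C@@]1(O)CC[C@H]2c1ccc(OS(=O)(=O)c2ccc(C)cc2)c(C)c1[C@@H]3Cn1cc(-c2ccc(C)cc2)nn1` gives > 20000 nM in a functional assay on SMMC-7721 cells (Homo sapiens) for cytotoxicity, read by MTT assay, with a stated time of 4 days (on this read-out higher numbers stand for weaker inhibition and lower numbers for stronger inhibition), a limit of the assay and not a number.
Compound 2 `C=C1C[C@]23C[C@@]1(O)CC[C@H]2c1ccc(O)c(C)c1[C@@H]3Cn1cc(-c2ccc(C)cc2)nn1` gives > 20000 nM in this assay, again only a limit.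
Compound 3 `COc1ccc(-c2cn(C[C@H]3c4c(ccc(O)c4C)[C@@H]4CC[C@@]5(C)C[C@]43CC5=O)nn2)cc1` gives > 20000 nM in this assay, likewise a limit.

Compound 1 therefore stands nowhere in particular: all that is known is the limit of > 20000 nM in this assay, at which 3 of the 3 values shown sit. Going by the values given here, the single step between measured compounds that differ in one place, a step that the two limits leave unreadable from compound 1 to compound 2, is hydrogen in place of (4-methylphenyl)sulfonyl on the phenolic oxygen, and the two limits leave its size unreadable. Compound 3 differs from compound 2 in several places at once, and its two values show nothing beyond two limits.

Compound 4 `C=C1C[C@]23C[C@@]1(O)CC[C@H]2c1ccc(OS(=O)(=O)c2ccc(C)cc2)c(C)c1[C@@H]3Cn1cc(-c2ccccn2)nn1` carries the change (pyridin-2-yl in place of 4-methylphenyl on an aromatic carbon). Among the compounds with values here, no measured step touches the aryl group on the triazole, so nothing among the measured compounds bears on it, and no direction can be read. Since compound 1 and its companions all sit at the limit, compound 4 is expected to sit there too, with an estimate of 20000 nM, ranging from 5000 nM to 80000 nM, which is the expected step of a number no higher from compound 1 to compound 4 (the limit leaves the size open).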

Compound 4, half-maximal inhibitory concentration: > 20000 nM
Compound 4: a limit, no number; the forecaster's own chance of this, stated with the estimate: 75%; the middle value sits exactly at the limit.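

No step can be read between compound 1 and compound 4 because both rest on limits of the assay, not numbers: the limit of > 20000 nM in this assay, at which 4 of the 4 values shown sit.

The compounds shown leave open whether pyridin-2-yl in place of 4-methylphenyl changes cytotoxicity at all, and what change on the shared core would bring a measurable number.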